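A few compounds are considered here, and "the series" means these few. Any claim that something is new, unique, unknown or untested is made for them only; others in the source may bear on it.

Measured so far in a functional assay on XF498 cells (Homo sapiens) for cytotoxicity; on this read-out lower numbers stand for an effect already at smaller amounts and higher numbers for an effect only at larger amounts of compound:
- compound 1 `C#C/C=C\CCCCCCCCCCCCCC/C=C/CCCC/C=C/CCCCC#C[C@@H](O)C#CCCCCCC/C=C/[C@H](O)C#C`: 1.7 ug/mL
- compound 2 `C#C/C=C\CCCCCCCCCCCCCC/C=C/CCCC/C=C/CC/C=C/C#C[C@@H](O)C#CCCCCCC/C=C/[C@H](O)C#C`: 1.7 ug/mL

Compound 1 stands level with compound 2 in this read-out, with no difference at the digits shown and nothing beyond the scatter. Those two values are the only reference points, and neither one marks out a compound as ahead of the other.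

The next compound to be tested is compound 3 `C#C/C=C\CCCCCCCCCCCCCC/C=C/CCCC/C=C/CCCCC#C[C@@H](O)C#CCCCCCCCC[C@H](O)C#C`. It departs from compound 1 at a single place: a group of 6 heavy atoms (5 carbon, 1 oxygen; no ring) in place of a group of 6 heavy atoms (5 carbon, 1 oxygen; no ring), on a saturated chain carbon, six bonds along the chain from a triple-bonded carbon. The rest of the long chain stays as it is in compound 1.

Within the data shown here, no measured pair shows what a change of this kind does in this assay, so the data offer no direct precedent. The expectation therefore starts from compound 1 at 1.7 ug/mL, and it allows for a small drift towards higher numbers, though no change beyond the scatter would be unsurprising. The expected 1.4-fold higher number from compound 1 to compound 3 (0.13 log units; within the scatter) is modest. For compound 3 the estimated value is 2.3 ug/mL, with an expected range from 1 ug/mL to 5.5 ug/mL.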

Compound 3, concentration for half-maximal effect: > 3 ug/mL
Compound 3: a limit, no number (the forecaster's own chance of this, stated with the estimate: 5%); middle value at least 1.3-fold (0.11 log units) from the limit.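

In this assay compound 3 gives > 3 ug/mL, which is a limit of the assay and not a number. Measured against compound 1, the change is an at least 1.7-fold higher number from compound 1 to compound 3 (0.24 log units; that floor lies within the scatter), and it gives the first view of this place, on a saturated chain carbon, six bonds along the chain from a triple-bonded carbon: the entering group carries 1 triple bond and no double bond, where the leaving group carried 1 double bond and 1 triple bond. Only a floor is known for this step and that floor lies within the scatter, so the result neither shows that removing the double bond moves the read-out in this assay beyond the scatter nor rules it out: the limit of > 3 ug/mL in this assay, at which 1 of the 3 values shown sits.

Going by these compounds, the size of the step remains open, since a number for compound 3 would be needed to tell a change within the scatter from a larger one. Also open, on these data alone, is how this place would respond to a different group, such as a longer chain, or a carbonyl or an amine on the same stretch of chain.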